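Shortening the alkyl group on the imine nitrogen

A few compounds are considered here, and "the series" means these few. Any claim that something is new, unique, unknown or untested is made for them only; others in the source may bear on it.

Compound 1 `CCC(C)(C)/N=c1\c(O)c(O)\c1=N/Cc1c(Cl)cccc1Cl` and compound 3 `CC(C)(C)/N=c1\c(O)c(O)\c1=N/Cc1ccc(C#N)cc1` share a core, but the difference between the two cores is not broken down here. In a functional assay for inhibition, with Rattus norvegicus as the target (a higher number here means a weaker inhibitor, a lower number a stronger inhibitor), compound 1 gives 280 nM, and compound 3 gives 270 nM; these two numbers lie within the scatter of each other. Compound 2 `CC(C)(C)/N=c1\c(O)c(O)\c1=N/Cc1c(Cl)cccc1Cl` differs from compound 1 by hydrogen in place of methyl on a saturated chain carbon, two bonds along the chain from a double-bonded nitrogen and in this assay compound 2 gives 1100 nM, so that a 3.9-fold higher number from compound 1 to compound 2 (0.59 log units; beyond the scatter).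

Compound 4 `CC(C)/N=c1\c(O)c(O)\c1=N/Cc1ccc(C#N)cc1` has not yet been measured. It differs from compound 3 by hydrogen in place of methyl on a saturated chain carbon bound to a double-bonded nitrogen and two saturated chain carbons. Going by the values given here, this is the same kind of change as the one from compound 1 to compound 2, yet the place is not the same: in compound 1 the methyl leaves a saturated chain carbon two bonds along the chain from the double-bonded nitrogen, whereas in compound 3 the methyl leaves a saturated chain carbon bound directly to the double-bonded nitrogen and to two saturated chain carbons.

Because a 3.9-fold higher number from compound 1 to compound 2 (0.59 log units; beyond the scatter), the removal of a methyl from this alkyl group is expected to weaken inhibition in this assay, and a step of a 3.7-fold higher number from compound 3 to compound 4 (0.57 log units; beyond the scatter) is estimated here. The number for compound 4 in this assay is therefore expected to be about 1000 nM, estimated to lie between 400 nM and 3000 nM; only compounds 1, 2 and 3 support this expectation.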

Compound 4, half-maximal inhibitory concentration: 14000 nM
Compound 4: the middle estimate sits 14-fold (1.15 log units) below what was measured; the measured number lies above the stated range.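

Taking tert-butyl to isopropyl in this assay gives a 52-fold higher number from compound 3 to compound 4 (1.71 log units; beyond the scatter), and this step does not match the earlier removal of a methyl from the same alkyl group: the same change on two cores in this assay, a 3.9-fold higher number (0.59 log units; beyond the scatter) from compound 1 to compound 2 and a 52-fold higher number (1.71 log units; beyond the scatter) from compound 3 to compound 4, 13-fold (1.12 log units) apart, beyond the scatter of two such steps

The direction carries over between the two cores, with a higher number, and so a weaker inhibitor, in both steps, but the size does not, so the step on the core of compound 1 does not set the size of the step on the core of compound 3. These two steps do not show why the sizes part, since the methyl leaves a different place in each and the two pairs also differ in the group on the other nitrogen, so place and core cannot be told apart here, and two pairs make no rule for the series.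

The compounds shown leave open what the alkyl group of compound 1 would give on the core of compound 3, the one comparison that would bring the two steps onto a single core. They also leave open how a cyclopropyl group, an ethyl group or a longer chain on this nitrogen would compare with the tert-butyl group of compound 3.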